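The source may report more compounds than this note shows. Statements on the series, on what has been measured and on what is new or still open speak of the compounds shown alone.

- Compound 1 `Cc1cc(NC(=O)Nc2ccc(C(C)(C)C)cc2)c2ccccc2n1`: 20000 nM
- Compound 2 `Cc1cc(NC(=O)Nc2cccc([N+](=O)[O-])c2)c2ccccc2n1`: > 25000 nM
- Compound 3 `COc1ccc(NC(=O)Nc2cc(C)nc3ccccc23)cc1OC`: > 25000 nM

Among the measured compounds shown here, in an ADME assay on BJ cells (Homo sapiens) for cytotoxicity, with a stated time of 72 h (a higher number here means that more compound is needed for the effect, a lower number that less compound is needed), compound 1 gives 20000 nM, the only actual number among the three measured compounds. Compound 2 gives > 25000 nM, which is a limit of the assay and not a number. Compound 3 gives > 25000 nM, again a limit. The series is thus framed by the limit of > 25000 nM in this assay, at which 2 of the 3 values shown sit.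

Compound 4 `Cc1ccc(NC(=O)Nc2cc(C)nc3ccccc23)cc1` has not yet been measured in this assay. It differs from compound 1 at a single place, with methyl in place of tert-butyl on an aromatic carbon. For the measured compounds named here, no measured pair isolates this change, so only a loose expectation is possible: a small upward step in this assay, not far beyond the scatter. That expectation leans on compound 3, which carries no tert-butyl and stands at the limit > 25000 nM. The expected change is a 1.4-fold higher number from compound 1 to compound 4 (0.13 log units; within the scatter). For compound 4 the estimated value is 27000 nM, with an expected range of 15000 nM to 50000 nM.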

Compound 4, half-maximal effective concentration: > 25000 nM
Compound 4: only a limit was reported; the forecaster's own chance of this, stated with the estimate: 65%; the middle value does not contradict the limit.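

In this assay compound 4 gives > 25000 nM, which is a limit of the assay and not a number. Methyl in place of tert-butyl, para to a large group, is the only change at this position that can be read, and it amounts to an at least 1.2-fold higher number from compound 1 to compound 4 (0.09 log units; that floor lies within the scatter), so the true size of the step stays open and no real change can be claimed. Compound 1 remains the only compound with an actual number, and the series gathers further at one limit: the limit of > 25000 nM in this assay, at which 3 of the 4 values shown sit.

The compounds shown do not tell whether an amine or a carboxylic acid at this place would bring the number clearly into the measurable range. They also leave open whether a longer chain than tert-butyl would give a number different from that of compound 1.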